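From an Indole to a Quinoline on the Amine Nitrogen

This account rests on a few compounds, and the source may have more. Where it says the series, first, only, none or still open, it means among the compounds named here.

Of the compounds shown here, three with a shared core have been measured. Compound 1 `O=C(/C=C\Nc1ccc(F)cc1)c1nc(-c2ccc(F)cc2)n2ccccc12` carries a fluorophenyl amine. In a functional assay on B16-F10 cells (Mus musculus) for cytotoxicity, read by MTT assay, with a stated time of 48 h (on this read-out lower numbers stand for stronger inhibition and higher numbers for weaker inhibition), compound 1 gives > 30000 nM, which is a limit of the assay and not a number (the limit of > 30000 nM in this assay, at which 1 of the 3 values shown sits). Compound 2 `COc1ccc(-c2nc(C(=O)/C=C\Nc3ccc4[nH]ccc4c3)c3ccccn23)cc1` carries an indolyl amine and in this assay compound 2 gives 5120 nM. Compound 3 `O=C(/C=C\Nc1ccc2[nH]ccc2c1)c1nc(-c2ccc(C(F)(F)F)cc2)n2ccccc12` gives 18200 nM in this assay, the higher of the two numbers shown, and the step of a 3.6-fold higher number from compound 2 to compound 3 (0.55 log units; beyond the scatter) is the only measured step in the set.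

Compound 4 `O=C(/C=C\Nc1cnc2ccccc2c1)c1nc(-c2ccc(C(F)(F)F)cc2)n2ccccc12` differs from compound 3 in one place: quinolin-3-yl in place of 1H-indol-5-yl on an amine nitrogen. Among the measured compounds shown here, no measured pair shows this exchange, and the one measured step concerns a substituent elsewhere on the core, so it gives no direct guidance. The account therefore expects the step of a 1.2-fold higher number from compound 3 to compound 4 (0.08 log units; within the scatter) to stay close to the scatter, with a wide range. For compound 4 in this assay the estimate is 22000 nM, expected to lie between 7000 nM and 30000 nM.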

Compound 4, half-maximal inhibitory concentration: > 30000 nM
Compound 4: a limit, no number (the forecaster's own chance of this, stated with the estimate: 40%); at least 1.3-fold (0.13 log units) between middle value and limit.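

In this assay compound 4 gives > 30000 nM, which is a limit of the assay and not a number. Quinolin-3-yl in place of 1H-indol-5-yl on the amine nitrogen is the first change at this position that can be read as a step, and it appears as an at least 1.6-fold higher number from compound 3 to compound 4 (0.21 log units; that floor lies within the scatter), so only a floor is known and the true size of the step stays open. Compound 4 now stands with compound 1 at the limit: the limit of > 30000 nM in this assay, at which 2 of the 4 values shown sit.

The compounds shown leave open whether quinolin-3-yl would give a number alongside the methoxy group of compound 2 instead of trifluoromethyl. They also do not tell how a benzylamine or a morpholine on this position would read out.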